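Hydrazone aryl variation on the shared core

The source may report more compounds than this note shows. Statements on the series, on what has been measured and on what is new or still open speak of the compounds shown alone.

Compound 3 `CN(C)CCn1cnnc1-c1cc(Oc2ccc(NC(=O)N/N=C/c3ccc(Cl)cc3)cc2F)ccn1` carries the lowest number of the three measured in a functional assay on NCI-H460 cells (Homo sapiens) for cytotoxicity, read by MTT assay, with a stated time of 72 h (a lower number here means a stronger inhibitor, a higher number a weaker inhibitor), where compound 3 gives 320 nM. Compound 1 `CN(C)CCn1cnnc1-c1cc(Oc2ccc(NC(=O)N/N=C/c3c(Cl)cccc3Cl)cc2F)ccn1` stands within the scatter of it, as the step of a 1.1-fold lower number from compound 1 to compound 3 (0.04 log units; within the scatter) shows; in this assay compound 1 gives 350 nM. Compound 2 `CN(C)CCn1cnnc1-c1cc(Oc2ccc(NC(=O)N/N=C/c3ccccc3)cc2F)ccn1` sits apart: in this assay compound 2 gives 1780 nM, and the step of a 5.1-fold higher number from compound 1 to compound 2 (0.71 log units; beyond the scatter) is beyond the scatter.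

Compound 4 `Cc1cc(/C=N/NC(=O)Nc2ccc(Oc3ccnc(-c4nncn4CCN(C)C)c3)c(F)c2)cc(C)c1O` has not yet been measured in this assay. Its change from compound 3 is 4-hydroxy-3,5-dimethylphenyl in place of 4-chlorophenyl on a carbon with a double bond to nitrogen. Among the compounds with values here, the step of a 5.6-fold lower number from compound 2 to compound 3 (0.75 log units; beyond the scatter) is the only measured step that concerns a substituent on this phenyl ring, and it is modest. Within the data shown here, no measured step covers the entering hydroxy group or the two methyl groups, so the direction is uncertain. The step to compound 4 is therefore expected to be small, weighted toward a higher number: a 1.6-fold higher number from compound 3 to compound 4 (0.19 log units; within the scatter). Compound 4 is estimated at 500 nM, with an expected range from 120 nM to 2000 nM.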

Compound 4, half-maximal inhibitory concentration: 2010 nM
For compound 4 the middle estimate is 4.0-fold (0.60 log units) below the measured one; the measured number lies above the stated range.
By their numbers in this assay, from the lowest: compounds 3 and 1 (each within the scatter of the next); then compounds 2 and 4 (each within the scatter of the next).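

In this assay, a substituted ring at this position does not by itself give a low number: a 6.3-fold higher number from compound 3 to compound 4 (0.80 log units; beyond the scatter) and a 5.7-fold higher number from compound 1 to compound 4 (0.76 log units; beyond the scatter) both show 4-hydroxy-3,5-dimethylphenyl falling short of the two chlorinated rings. Against unsubstituted phenyl, a 1.1-fold higher number from compound 2 to compound 4 (0.05 log units; within the scatter) shows no separation, so among these four compounds the low numbers belong only to the two chlorine-bearing rings, and the hydroxy group and two methyl groups together leave the number where phenyl has it. Nothing measured here bears on the reason for this result.

The hydroxy group and the two methyl groups enter together, so their separate contributions cannot be told apart from these compounds. Also open, from the compounds shown here alone, is how this position responds to a ring carrying an amine, a carboxylic acid or a methoxy group.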